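From Pyrazolyl to Methoxyphenyl on the Amino Nitrogen

The compounds below may be only part of what the source reports. "The series", "measured", "known", "first", "only" and "open" are said of these compounds alone.

In an ADME assay on L02 cells (Homo sapiens) for cytotoxicity, read by MTT assay, with a stated time of 72 h (on this read-out higher numbers stand for weaker inhibition and lower numbers for stronger inhibition), compound 2 (`CC(C)/C=C/C(=O)Nc1cccc(Oc2nc(Nc3ccn(C)n3)nc3c2CSCC3)c1`) gives > 50000 nM as a limit of the assay, not a number. Compound 1 (`CCC/C=C/C(=O)Nc1cccc(Oc2nc(Nc3ccn(C)n3)nc3c2CSCC3)c1`) gives > 50000 nM as a limit too. Compound 3 (`C=C(F)C(=O)Nc1cccc(Oc2nc(Nc3ccn(C)n3)nc3c2CSCC3)c1`) gives 47800 nM as a measured number. Compound 2 thus shares the limit of > 50000 nM in this assay, at which 2 of the 3 values shown sit, and offers no exact starting point. Compound 4 (`COc1cccc(Nc2nc3c(c(Oc4cccc(NC(=O)/C=C/C(C)C)c4)n2)CSCC3)c1`) carries 3-methoxyphenyl in place of 1-methyl-1H-pyrazol-3-yl on a nitrogen on an aromatic ring. The measured steps alter only the group on the carbonyl carbon: one is a step that the two limits leave unreadable from compound 1 to compound 2 and another is an at least 1.0-fold lower number from compound 2 to compound 3 (0.01 log units; that floor lies within the scatter) and neither sizes this change. Only a modest move toward a lower number is therefore expected in this assay and another limit remains possible. What is expected is an at least 1.4-fold lower number from compound 2 to compound 4 (0.15 log units; that floor lies within the scatter) on this reading. For compound 4 the estimate is 35000 nM with an expected range from 12000 nM to 70000 nM overall.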

Compound 4, half-maximal inhibitory concentration: > 50000 nM
Compound 4: a limit, no number; the forecaster's own chance of this, stated with the estimate: 45%; middle value at least 1.4-fold (0.15 log units) from the limit.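

No new step can be read between compound 2 and compound 4, because both stand at a limit and give no number: the limit of > 50000 nM in this assay, at which 3 of the 4 values shown sit.

The compounds shown leave open how large any effect of 3-methoxyphenyl in place of 1-methyl-1H-pyrazol-3-yl is on this read-out.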